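This account rests on a few compounds, and the source may have more. Where it says the series, first, only, none or still open, it means among the compounds named here.

Measured in a functional assay on A549 cells (Homo sapiens) for antiproliferative activity, read by MTT assay; a higher number here means a weaker inhibitor, a lower number a stronger inhibitor:
- compound 1 `COc1ccc(-n2cc(COc3ccc(/C=C/C(=O)c4cc5c(cc4O)OC(C)(C)CC5)cc3)nn2)c([N+](=O)[O-])c1`: 99500 nM
- compound 2 `Cc1ccc(-n2cc(COc3ccc(/C=C/C(=O)c4ccc5c(c4O)CCC(C)(C)O5)cc3)nn2)cc1Br`: "not active" (no number reported)

Among the compounds with values here, compound 1 carries the only number in this small set, so it can be ranked against no other measured value. Compound 2 has an entry without a number, which gives no size of difference. Within the data shown here, no step between measured compounds is available, so the series offers no direct guide to how much a change on this part of the structure moves the read-out.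

The next compound is compound 3 `CC1(C)CCc2cc(C(=O)/C=C/c3ccc(OCc4cn(Cc5ccc([N+](=O)[O-])cc5)nn4)cc3)c(O)cc2O1`. It keeps the core of compound 1, and 4-nitrobenzyl comes in place of 4-methoxy-2-nitrophenyl on an aromatic nitrogen of a five-membered aromatic ring with 3 nitrogen: 4-nitrobenzyl in place of 4-methoxy-2-nitrophenyl on an aromatic nitrogen.

Compound 1 already reads weakly at 99500 nM, so any numeric result is expected to lie near it or on the stronger side, with a real chance of no number at all, as for compound 2. The estimated step of a 2.2-fold lower number from compound 1 to compound 3 (0.34 log units; beyond the scatter) is expected to be modest and towards a stronger inhibitor, though it may not clear the scatter by much. For compound 3 the expected value is 45000 nM, within an estimated range of 10000 nM to 130000 nM.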

Compound 3, half-maximal inhibitory concentration: 35800 nM
For compound 3 the middle estimate is 1.3-fold (0.10 log units) above the measured one; the range from low to high includes it.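

In this assay, the group on an aromatic nitrogen of the five-membered aromatic ring with 3 nitrogen now has a first measured effect: 4-nitrobenzyl in place of 4-methoxy-2-nitrophenyl gives a 2.8-fold lower number from compound 1 to compound 3 (0.44 log units; beyond the scatter), so the read-out responds to a change at this position while the core of compound 1 stays the same. The change replaces a directly attached aromatic ring with a benzyl group, removes the methoxy group and alters the placement of the nitro group, so this one step cannot show which difference carries the shift, and compound 3 at 35800 nM remains a weak inhibitor. No measurement available here explains the shift.

On these data alone, it remains open whether the shift follows from the benzyl link or from the substituents on the aromatic ring, a question that unsubstituted benzyl, 4-methoxybenzyl or a longer chain such as 2-phenylethyl could help separate. As far as these compounds go, it is also open how an amine or a carboxylic acid on the benzyl ring would move the number in this assay.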